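Chloro for Fluoro: Cytotoxicity Across Two Cores

The compounds below may be only part of what the source reports. "The series", "measured", "known", "first", "only" and "open" are said of these compounds alone.

Compound 1 `O=C1CSC(c2c(F)cccc2Cl)N1C(=O)Nc1ccncc1` and compound 2 `O=C1CSC(c2c(Cl)cccc2Cl)N1C(=O)Nc1ccncc1` share one core, while compound 3 `COc1cc(OC)nc(N2C(=O)CSC2c2c(F)cccc2F)n1` and compound 4 `COc1cc(OC)nc(N2C(=O)CSC2c2c(F)cccc2Cl)n1` share another; the difference between the two cores is not broken down here. In an ADME assay on TZM cells (Homo sapiens) for cytotoxicity, read by MTT assay, with a stated time of 48 h (on this read-out higher numbers stand for lower toxicity in this test and lower numbers for higher toxicity in this test), compound 1 gives 105000 nM and compound 2 gives 170000 nM. The change between them, (chloro in place of fluoro on an aromatic carbon), produced a 1.6-fold higher number from compound 1 to compound 2 (0.21 log units; within the scatter). In this assay compound 3 gives 77500 nM. Compound 4 differs from compound 3 by chloro in place of fluoro on an aromatic carbon. The surroundings are not identical: in compound 1 the changed carbon is meta to a chloro group, whereas in compound 3 it is meta to a fluoro group, so the two changes are the same kind of change rather than the same. Because the earlier pair showed a 1.6-fold higher number from compound 1 to compound 2 (0.21 log units; within the scatter), the step from compound 3 to compound 4 is expected to be of a similarly small size, a 1.4-fold higher number from compound 3 to compound 4 (0.13 log units; within the scatter), an expectation resting on that single earlier pair alone. Compound 4 is therefore estimated at 105000 nM, most likely between 55000 nM and 200000 nM.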

Compound 4, half-maximal cytotoxic concentration: 98200 nM
Compound 4: the middle estimate sits 1.1-fold (0.03 log units) above what was measured, and the stated range covers the measured number.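

In this assay, placing chloro where fluoro stood on an aromatic carbon again gave only a small step, a 1.3-fold higher number from compound 3 to compound 4 (0.10 log units; within the scatter). Set side by side, the steps on the two cores do not differ by more than the test can resolve: the same change on two cores in this assay, a 1.6-fold higher number (0.21 log units; within the scatter) from compound 1 to compound 2 and a 1.3-fold higher number (0.10 log units; within the scatter) from compound 3 to compound 4, 1.3-fold (0.11 log units) apart, within the scatter of two such steps. So, on these two pairs, the change carries over from the core of compound 1 to the core of compound 3 without a detectable difference in size, but neither step stands clear of the scatter, so this does not show that chloro in place of fluoro truly raises the number on either core, and two pairs set no rule for any other core in the series.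

The compounds shown leave open whether a bromo or a methyl group at the same place would also leave the number close to that of compound 3. On these data alone, it also remains open whether an amine or a carboxylic acid there would produce a step beyond the scatter.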